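The source may hold more compounds than are shown below. What is called first, only, known or untested is meant among the compounds shown, and "the series" means these compounds.

Compound 1 `CC[C@@H]1c2cc(Cl)ccc2C(=O)N1c1cncc2c1CCC[C@H]2NC(C)=O` is the reference here. In an assay on cells for inhibition of cytochrome P450 11B2, mitochondrial (Homo sapiens), read by HTRF (on this read-out lower numbers stand for stronger inhibition and higher numbers for weaker inhibition), compound 1 gives 7 nM, the lowest of the three measured numbers. Compound 2 `CC(=O)N[C@@H]1CCCc2c1cncc2N1C(=O)c2ccc(Cl)cc2[C@H]1C` gives 130 nM in this assay, and compound 3 `CC(=O)N[C@@H]1CCCc2c1cncc2N1C(=O)c2ccc(Cl)cc2[C@H]1C1CC1` gives 100 nM; the steps of a 19-fold higher number from compound 1 to compound 2 (1.27 log units; beyond the scatter) and a 14-fold higher number from compound 1 to compound 3 (1.15 log units; beyond the scatter) are both large, whereas the step of a 1.3-fold lower number from compound 2 to compound 3 (0.11 log units; within the scatter) stays within the scatter. Within the data shown here, compound 4 `CC[C@H]1c2cc(Cl)ccc2C(=O)N1c1cncc2c1CCC[C@H]2NC(C)=O` has not yet been measured. the two compounds have the same atoms and bonds and differ only in configuration as drawn: 1 of 2 stereo elements differ; a stereocentre at a saturated ring carbon is drawn R in compound 1 and S in compound 4 No measured pair shows an inversion of configuration, so no step bears directly on this change. What the measured steps do show is that the saturated ring carbon in question is a sensitive place, as the steps of a 19-fold higher number from compound 1 to compound 2 (1.27 log units; beyond the scatter) and a 14-fold higher number from compound 1 to compound 3 (1.15 log units; beyond the scatter) both make clear. Turning the ethyl-bearing stereocentre the other way is therefore expected to weaken inhibition, and the step of a 14-fold higher number from compound 1 to compound 4 (1.15 log units; beyond the scatter) is the estimate that follows. Compound 4 is thus expected to give 100 nM, with a range from 15 nM to 600 nM.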

Compound 4, half-maximal inhibitory concentration: 97 nM
Compound 4: middle estimate off by 1.0-fold (0.01 log units), on the high side; the range from low to high includes it.
By their numbers in this assay, from the lowest: compound 1; then compounds 4, 3 and 2 (each within the scatter of the next).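

The earlier steps shown here replaced the group on this saturated ring carbon, whereas this one keeps the ethyl and only turns it the other way. In this assay, among these compounds, that turn alone gives a 14-fold higher number from compound 1 to compound 4 (1.14 log units; beyond the scatter), about as large as the earlier steps that replaced the group, so ethyl by itself does not secure the low number of compound 1 and its configuration matters as well. The whole step can be assigned to configuration at this one carbon, because nothing else separates the pair: the fact that compounds 1 and 4 differ only in the configuration as drawn.

The compounds shown leave open how a longer chain such as propyl, or an amine, would fare on this carbon in either configuration. They also leave open what inverting the other stereo element, the one carrying the acetamide, would do.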